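This account rests on a few compounds, and the source may have more. Where it says the series, first, only, none or still open, it means among the compounds named here.

Measured compounds in a functional assay on A549 cells (Homo sapiens) for antiproliferative activity, read by MTT assay, with a stated time of 48 h; on this read-out higher numbers stand for weaker inhibition and lower numbers for stronger inhibition:
- compound 1 `O=C(/C=C/c1ccccc1)Nc1ccc2ncnc(Nc3cccc(Br)c3)c2c1`: compound 1 gives 3.96 ug/mL
- compound 2 `O=C(/C=C/c1cccs1)Nc1ccc2ncnc(Nc3cccc(Br)c3)c2c1`: compound 2 gives 4.66 ug/mL
- compound 3 `Cc1ccc(/C=C/C(=O)Nc2ccc3ncnc(Nc4cccc(Br)c4)c3c2)cc1`: compound 3 gives 3.01 ug/mL

Compound 3 gives the lowest of the three numbers, but the steps to it, a 1.3-fold lower number from compound 1 to compound 3 (0.12 log units; within the scatter) and a 1.5-fold lower number from compound 2 to compound 3 (0.19 log units; within the scatter), both lie within the scatter, as does a 1.2-fold higher number from compound 1 to compound 2 (0.07 log units; within the scatter). Compound 4 `Cc1ccc(/C=C/C(=O)Nc2ccc3ncnc(Nc4cccc(Cl)c4)c3c2)cc1` is the next compound; it differs from compound 3 by chloro in place of bromo on an aromatic carbon. Within the data shown here, none of the measured steps touches this halogen, and every measured change elsewhere in the molecule stayed within the scatter. There is therefore no ground to expect a step beyond the scatter in this assay in either direction, so the estimate is a 1.1-fold higher number from compound 3 to compound 4 (0.03 log units; within the scatter). Compound 4 is expected to give about 3.2 ug/mL, between 1.5 ug/mL and 6.5 ug/mL.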

Compound 4, half-maximal inhibitory concentration: 6.03 ug/mL
For compound 4 the middle estimate is 1.9-fold (0.28 log units) below the measured one, and the stated range covers the measured number.
By their numbers in this assay, from the lowest: compounds 3, 1, 2 and 4 (each within the scatter of the next).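

This is the first change shown at the halogen, and in this assay it gives a 2.0-fold higher number from compound 3 to compound 4 (0.30 log units; within the scatter), the largest step so far but still within the usual scatter. Chloro in place of bromo at this place therefore shows no clear effect, though a small real one cannot be ruled out. No measurement here explains the size of this step.

As far as these compounds go, whether fluoro, methoxy or an amine at this place would move the number beyond the scatter remains open. Also open, from the compounds shown here alone, is whether chloro in place of bromo gives a similar step when the chain ends in phenyl or thiophen-2-yl instead of 4-methylphenyl.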